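A few compounds are considered here, and "the series" means these few. Any claim that something is new, unique, unknown or untested is made for them only; others in the source may bear on it.

Compound 1 `COc1cc2ncnc(N3CCc4ccccc43)c2cc1NC(=O)/C=C/CN1CCCCC1`: 2540 nM
Compound 2 `COc1cc2ncnc(N3CCc4ccccc43)c2cc1NC(=O)/C=C/CN1CCN(C)CC1`: 5360 nM
Compound 3 `O=C(/C=C/CN1CCCCC1)Nc1cc2c(N3CCc4ccccc43)ncnc2cc1O[C@@H]1CCOC1`: 4660 nM

All three were measured in a functional assay on A549 cells (Homo sapiens) for antiproliferative activity, read by MTT assay, with a stated time of 72 h; on this read-out lower numbers stand for stronger inhibition and higher numbers for weaker inhibition. Compound 2 is derived from compound 1 by the change (4-methylpiperazin-1-yl in place of piperidin-1-yl on a saturated chain carbon bound to a double-bonded chain carbon), and that step reads a 2.1-fold higher number from compound 1 to compound 2 (0.32 log units; beyond the scatter). Compound 3 differs from compound 1 in its core by oxolan-3-yl in place of methyl on an oxygen on an aromatic ring, a step of a 1.8-fold higher number from compound 1 to compound 3 (0.26 log units; within the scatter). Compound 4 `CN1CCN(C/C=C/C(=O)Nc2cc3c(N4CCc5ccccc54)ncnc3cc2O[C@@H]2CCOC2)CC1` has not yet been measured; it is derived from compound 3 by 4-methylpiperazin-1-yl in place of piperidin-1-yl on a saturated chain carbon bound to a double-bonded chain carbon, the same change that led from compound 1 to compound 2, at the same place. Among the measured compounds shown here, with only that one earlier example, compound 4 is expected to show a similar step: a 2.0-fold higher number from compound 3 to compound 4 (0.31 log units; beyond the scatter), resting on a 2.1-fold higher number from compound 1 to compound 2 (0.32 log units; beyond the scatter) and on the value of compound 3, 4660 nM. Compound 4 is therefore estimated at 9500 nM, between 4500 nM and 20000 nM.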

Compound 4, half-maximal inhibitory concentration: 6090 nM
The estimate for compound 4 lay 1.6-fold (0.19 log units) above the measured number, within the range that was stated.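

In this assay, 4-methylpiperazin-1-yl in place of piperidin-1-yl gives a 1.3-fold higher number from compound 3 to compound 4 (0.12 log units; within the scatter), and the two readings of this change do not differ beyond the scatter: the same change on two cores in this assay, a 2.1-fold higher number (0.32 log units; beyond the scatter) from compound 1 to compound 2 and a 1.3-fold higher number (0.12 log units; within the scatter) from compound 3 to compound 4, 1.6-fold (0.21 log units) apart, within the scatter of two such steps. Oxolan-3-yl in place of methyl on an oxygen on an aromatic ring gives a 1.1-fold higher number from compound 2 to compound 4 (0.06 log units; within the scatter), and this change also reads alike in both settings: the same change on two cores in this assay, a 1.8-fold higher number (0.26 log units; within the scatter) from compound 1 to compound 3 and a 1.1-fold higher number (0.06 log units; within the scatter) from compound 2 to compound 4, 1.6-fold (0.21 log units) apart, within the scatter of two such steps. The four compounds therefore show no detectable dependence of either change on the core, but two readings per change cannot establish that the steps transfer generally, and the new steps alone do not separate either change from the scatter.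

On these data alone, it remains open whether another amine on the chain, such as morpholin-4-yl or dimethylamino, would behave alike. The same question applies to a longer chain between the amine and the amide.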